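The source may hold more compounds than are shown below. What is called first, only, known or untested is meant among the compounds shown, and "the series" means these compounds.

Measured compounds in a functional assay on ileum for antagonist activity at histamine H1 receptor (Cavia porcellus); a higher number here means weaker binding, a lower number tighter binding: compound 1 `N=C(NCCCc1c[nH]cn1)NCCC(c1ccccc1)c1ccccn1`, compound 1 gives 97.7 nM; compound 2 `N=C(NCCCc1c[nH]cn1)NCCC(c1cccc(F)c1)c1ccccn1`, compound 2 gives 158 nM.

Among the measured compounds shown here, compound 1 has the lowest of the two numbers so far in this assay, yet its nearest neighbour, compound 2, is within the scatter of it, so the two cannot be ordered. For the measured compounds named here, the one measured step, a 1.6-fold higher number from compound 1 to compound 2 (0.21 log units; within the scatter), puts a fluoro in place of a hydrogen on an aromatic carbon of the phenyl ring and leaves the number essentially unchanged.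

Compound 3 `N=C(NCCCc1c[nH]cn1)NCCC(c1ccccc1)c1ccc(F)cc1` is not yet measured. It differs from compound 1 by 4-fluorophenyl in place of pyridin-2-yl on a saturated chain carbon bound to an aromatic carbon and a saturated chain carbon. Going by the values given here, only the step from compound 1 to compound 2 bears on this change, and only in part: it shows that a fluoro on the phenyl side costs little, whereas no measured pair speaks to exchanging the pyridin-2-yl ring for a carbon-only ring. The step of a 1.5-fold higher number from compound 1 to compound 3 (0.19 log units; within the scatter) is therefore expected to be small, with a wide uncertainty. Compound 3 is estimated at 150 nM in this assay, with a range from 40 nM to 600 nM.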

Compound 3, dissociation constant: 34.7 nM
Compound 3: middle estimate off by 4.3-fold (0.64 log units), on the high side; measured number below the stated range.
By their numbers in this assay, from the lowest: compound 3; then compounds 1 and 2 (each within the scatter of the next).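

In this assay, among the compounds shown here, 4-fluorophenyl in place of pyridin-2-yl on a saturated chain carbon bound to an aromatic carbon and a saturated chain carbon gives a 2.8-fold lower number from compound 1 to compound 3 (0.45 log units; beyond the scatter) and is the first step in this set to lie beyond the scatter, though it is a modest one. This shows that the number responds to the ring held at this position, which the fluoro exchange on the phenyl ring of compound 1 did not show, and that the pyridin-2-yl ring with its hydrogen-bond acceptor is not required for a number at this level, since a carbon-only ring without an acceptor gives a lower one. No available evidence gives a reason for this step.

The step combines two differences, the loss of the ring nitrogen and the arrival of a fluorine, so the compounds shown cannot divide it between them. On these data alone, it remains open how a plain phenyl, a 4-chlorophenyl or a pyridin-3-yl at this carbon would compare, and whether a longer or shorter chain would leave the step the same size.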